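The source may hold more compounds than are shown below. What is called first, only, known or untested is meant among the compounds shown, and "the series" means these compounds.

Measured so far in a functional assay on SK-MEL-28 cells (Homo sapiens) for inhibition, read by MTT assay, with a stated time of 48 h; a higher number here means a weaker inhibitor, a lower number a stronger inhibitor:
- compound 1 `COc1ccc(C/N=C2\NC(=O)/C(=C3\CCNC(=O)c4[nH]ccc43)S2)cc1`: 12100 nM
- compound 2 `O=C1N/C(=N\Cc2ccc(Cl)cc2)S/C1=C1/CCNC(=O)c2[nH]ccc21`: > 100000 nM

For the measured compounds named here, compound 1 holds the only actual number, 12100 nM. Compound 2 gives > 100000 nM, which is a limit of the assay and not a number. Compound 1 therefore has no measured neighbour to be ranked against, only (the limit of > 100000 nM in this assay, at which 1 of the 2 values shown sits).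

Not yet measured is compound 3 `CC(C)(C)c1ccc(C/N=C2\NC(=O)/C(=C3\CCNC(=O)c4[nH]ccc43)S2)cc1`, which carries tert-butyl in place of methoxy on an aromatic carbon, para to a large group (tert-butyl in place of methoxy on an aromatic carbon). Going by the values given here, one measured step bears on this change, since it replaces the same methoxy: an at least 8.2-fold higher number from compound 1 to compound 2 (0.91 log units; beyond the scatter). This is a single step and its true size is open, so it gives the direction better than the magnitude. On the evidence of an at least 8.2-fold higher number from compound 1 to compound 2 (0.91 log units; beyond the scatter), a higher number in this assay is expected for compound 3, meaning a weaker inhibitor, though a step within the scatter cannot be excluded. The expected change is a 2.3-fold higher number from compound 1 to compound 3 (0.36 log units; beyond the scatter). For compound 3 the estimated value is 28000 nM, with an expected range of 8000 nM to 100000 nM.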

Compound 3, half-maximal inhibitory concentration: 23500 nM
Compound 3: the middle estimate sits 1.2-fold (0.08 log units) above what was measured, within the range that was stated.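

In this assay, the change on the aromatic carbon para to a large group gives a 1.9-fold higher number from compound 1 to compound 3 (0.29 log units; within the scatter), so in this pair the exchange of methoxy for the larger tert-butyl, which also removes the hydrogen-bond acceptor counted for methoxy, produces no change that can be separated from the scatter. The other comparison at this place gives an at least 4.2-fold lower number from compound 2 to compound 3 (0.62 log units; beyond the scatter), which shows that replacing methoxy does not by itself bring the loss seen earlier: chloro goes against tert-butyl here, and the earlier step no longer reads as a general effect of leaving methoxy. Compound 2 sits at a limit of the assay and not at a number, so its steps fix only a minimum size: the limit of > 100000 nM in this assay, at which 1 of the 3 values shown sits.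

Going by these compounds, what sets chloro apart from methoxy and tert-butyl stays open, as three groups at one place do not define a trend in size or in hydrogen-bond acceptors. On these data alone, how an amine, a carboxylic acid or a hydroxyl at this same place would read in this assay also stays open, and so does whether a value well below that of compound 1 is reachable through this position at all.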